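Benzofuran for thiophene on an inactive nucleoside

The source may report more compounds than this note shows. Statements on the series, on what has been measured and on what is new or still open speak of the compounds shown alone.

Of the compounds shown here, two have been read so far in a functional assay on K562 cells (Homo sapiens), read by MTT assay, with a stated time of 72 h (on this read-out lower numbers stand for stronger inhibition and higher numbers for weaker inhibition), and neither gives a number. Compound 1 `CNc1ncnc2c1c(-c1cc3ccccc3o1)cn2[C@@H]1O[C@H](CO)[C@@H](O)[C@H]1O` gives > 20000 nM as a limit of the assay. Compound 2 `Nc1nc(N)c2c(-c3cccs3)cn([C@@H]3O[C@H](CO)[C@@H](O)[C@H]3O)c2n1` likewise gives > 20000 nM as a limit only. For the measured compounds named here, compound 2 thus stands at the limit of > 20000 nM in this assay, at which 2 of the 2 values shown sit, and offers no measured number to step from.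

Compound 3 `Nc1nc(N)c2c(-c3cc4ccccc4o3)cn([C@@H]3O[C@H](CO)[C@@H](O)[C@H]3O)c2n1` has 1-benzofuran-2-yl in place of thiophen-2-yl on an aromatic carbon, and 1-benzofuran-2-yl in place of thiophen-2-yl on an aromatic carbon is the counted change. No measured step sizes this swap in this assay. Compound 1 also carries 1-benzofuran-2-yl, and its > 20000 nM is a limit too, so no large gain is expected. The estimated step is a step that the limit leaves unreadable from compound 2 to compound 3 and is expected to stay within the scatter. Compound 3 is expected at 25000 nM with an estimated range of 8000 nM to 50000 nM and may well return only a limit.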

Compound 3, half-maximal inhibitory concentration: > 20000 nM
Compound 3 gave a limit, no number; the forecaster's own chance of this, stated with the estimate: 75%; the middle value does not contradict the limit.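

In this assay compound 2 and compound 3 both stand as limits of the assay, not numbers, so no step can be read for 1-benzofuran-2-yl in place of thiophen-2-yl. The compounds shown leave open whether this assay gives a number for any compound of this series.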